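Swapping a small group on an anilino ring

This account rests on a few compounds, and the source may have more. Where it says the series, first, only, none or still open, it means among the compounds named here.

Three close relatives of one shared core have been tested in an assay on FRT-Jurkat cells for inhibition of nuclear factor NF-kappa-B complex (Homo sapiens), read by flow cytometry, with a stated time of 24 h, tested at 10 uM; on this read-out lower numbers stand for less inhibition and higher numbers for more inhibition at the one concentration tested (going by the name of the read-out). Compound 1, `COc1ccc(Nc2cccc3c2C(=O)N(C2CCC(=O)NC2=O)C3=O)cc1`, gives 13%. Compound 2, `O=C1CCC(N2C(=O)c3cccc(Nc4ccc(O)cc4)c3C2=O)C(=O)N1`, gives 4%. Compound 3, `O=C1CCC(N2C(=O)c3cccc(Nc4ccccc4)c3C2=O)C(=O)N1`, gives 4%. Every step among them stays inside the scatter of repeated measurements: a number 9 percentage points lower from compound 1 to compound 2 (within the scatter), a number 9 percentage points lower from compound 1 to compound 3 (within the scatter) and no change at the digits printed from compound 2 to compound 3 (within the scatter). Compound 3 therefore sits level with compound 2 at the digits shown, and its distance from compound 1 is not a real difference.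

Compound 4, `Cc1ccc(Nc2cccc3c2C(=O)N(C2CCC(=O)NC2=O)C3=O)cc1`, has not yet been measured. It differs from compound 3 in one place: methyl in place of hydrogen on an aromatic carbon. Among the compounds with values here, the steps that bear on this change are those that altered the same ring position, methoxy to hydrogen and hydroxy to hydrogen, and both were flat. Nothing here suggests that a methyl there will behave differently, so no step beyond the scatter is expected in this assay; the expected step is a number 3 percentage points higher from compound 3 to compound 4 (within the scatter). Compound 4 is estimated at 7%, within a range from 0% to 18%.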

Compound 4, a percentage reported as inhibition, at one concentration (the size of the read-out at that concentration, not a potency): 9%
The estimate for compound 4 lay 2 percentage points below the measured number, and the stated range covers the measured number.
By their numbers in this assay, from the lowest: compounds 2, 3, 4 and 1 (each within the scatter of the next).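

Until now this ring position, para to a large group, had carried only hydrogen or a group attached through oxygen. Methyl puts a plain carbon there, and this assay shows a number 5 percentage points higher from compound 3 to compound 4 (within the scatter). Set against the oxygen-bearing groups, methyl gives a number 5 percentage points higher from compound 2 to compound 4 (within the scatter) and a number 4 percentage points lower from compound 1 to compound 4 (within the scatter). The flat picture at this position therefore now extends to a group attached through carbon, with hydrogen, hydroxy, methoxy and methyl all lying within the scatter of one another.

Open, on these data alone, is whether an amine, a carboxylic acid or a longer chain at the same position would move the number beyond the scatter. No available measurement offers an explanation for this flat picture.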